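This account rests on a few compounds, and the source may have more. Where it says the series, first, only, none or still open, it means among the compounds named here.

Three close relatives share one core and have been run through an in vitro ADME assay on microsomes from liver (Mus musculus) for pharmacokinetics, read by LC-MS, with a stated time of 10 min, tested at 1 uM; on this read-out lower numbers stand for slow clearance and higher numbers for fast clearance. Compound 1 `CN1C[C@H](C(=O)Nc2ccccc2)[C@@H](c2ccc(/C=C/C(=O)Nc3ccccc3N)cc2)C1` gives 67 mL/min/kg. Compound 2 `Cc1ccc(NC(=O)[C@H]2CN(C)C[C@@H]2c2ccc(/C=C/C(=O)Nc3ccccc3N)cc2)cc1` gives 62 mL/min/kg in this assay, and compound 3 `CN1C[C@H](C(=O)Nc2cccc(F)c2)[C@@H](c2ccc(/C=C/C(=O)Nc3ccccc3N)cc2)C1` gives 56 mL/min/kg. Compound 2 thus sits in the middle of the three numbers, and the two steps that lead away from it, a 1.1-fold lower number from compound 1 to compound 2 (0.03 log units; within the scatter) and a 1.1-fold lower number from compound 2 to compound 3 (0.04 log units; within the scatter), both lie within the scatter, so the three compounds are not told apart by this assay.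

Compound 4 `CN1C[C@H](C(=O)Nc2ccccc2F)[C@@H](c2ccc(/C=C/C(=O)Nc3ccccc3N)cc2)C1` has not yet been measured. It differs from compound 2 in one place: 2-fluorophenyl in place of 4-methylphenyl on an amide-type nitrogen. Within the data shown here, two measured steps bear on this. Placing a fluoro on the phenyl gave a 1.2-fold lower number from compound 1 to compound 3 (0.08 log units; within the scatter), and swapping the 4-methylphenyl for a fluorophenyl gave a 1.1-fold lower number from compound 2 to compound 3 (0.04 log units; within the scatter); neither moved the number beyond the scatter. Compound 4 is therefore expected to stay close to compound 2, with an estimated step of a 1.1-fold lower number from compound 2 to compound 4 (0.03 log units; within the scatter). The estimate for compound 4 in this assay is 58 mL/min/kg, within a range from 35 mL/min/kg to 95 mL/min/kg.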

Compound 4, clearance: 67 mL/min/kg
The estimate for compound 4 lay 1.2-fold (0.06 log units) below the measured number; low and high end bracket the measured number.
By their numbers in this assay, from the lowest: compounds 3, 2, 1 and 4 (each within the scatter of the next).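

Among these compounds, the 2-fluorophenyl group on the amide-type nitrogen does not separate compound 4 from the earlier compounds in this assay: the steps read no change at the digits printed from compound 1 to compound 4 (within the scatter), a 1.1-fold higher number from compound 2 to compound 4 (0.03 log units; within the scatter) and a 1.2-fold higher number from compound 3 to compound 4 (0.08 log units; within the scatter). The last of these adds something new, as it compares 2-fluorophenyl with 3-fluorophenyl, and this change of the fluoro's place on the phenyl also stays within the scatter. No supporting measurement is available to explain why these numbers sit so close together.

On these data alone, all four compounds carry a phenyl ring with only hydrogen, methyl or fluoro added, so it remains open whether a carboxylic acid or an amine on that ring, or a plain ethyl chain in its place, would move the number beyond the scatter. As far as these compounds go, whether a change elsewhere in the shared core would do so also remains open.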